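The source may hold more compounds than are shown below. What is called first, only, known or untested is meant among the compounds shown, and "the series" means these compounds.

Compound 3 `CCc1cccc(C)c1-n1nncc1CN1C(=O)C2(C(C#N)=C(N)Oc3c(N)cc4nc5ccccc5nc4c32)c2ccccc21` stands at a limit of a functional assay on MCF7 cells (Homo sapiens) for antiproliferative activity, read by MTT assay, with a stated time of 48 h (on this read-out lower numbers stand for stronger inhibition and higher numbers for weaker inhibition), rather than at a number: in this assay compound 3 gives > 50000 nM. Compound 1 `Cc1cccc(-n2nncc2CN2C(=O)C3(C(C#N)=C(N)Oc4c(N)cc5nc6ccccc6nc5c43)c3ccccc32)c1` also stands at a limit, giving > 50000 nM in this assay. Compound 2 `Cc1ccc(-n2nncc2CN2C(=O)C3(C(C#N)=C(N)Oc4c(N)cc5nc6ccccc6nc5c43)c3ccccc32)cc1C` likewise stands at a limit, giving > 50000 nM in this assay. Compound 4 `COc1ccc(OC)c(-n2nncc2CN2C(=O)C3(C(C#N)=C(N)Oc4c(N)cc5nc6ccccc6nc5c43)c3ccccc32)c1` differs from compound 3 by 2,5-dimethoxyphenyl in place of 2-ethyl-6-methylphenyl on an aromatic nitrogen. The measured steps that exchange the group on the aromatic nitrogen, a step that the two limits leave unreadable from compound 1 to compound 3 and a step that the two limits leave unreadable from compound 2 to compound 3, cannot be read, nor can a step that the two limits leave unreadable from compound 1 to compound 2, because all three values sit at the limit of > 50000 nM in this assay, at which 3 of the 3 values shown sit. With no readable step, no direction can be expected. The step is therefore expected to be a step that the limit leaves unreadable from compound 3 to compound 4. Compound 4 is expected to give 60000 nM, with a range from 20000 nM to 200000 nM, most likely again as a limit.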

Compound 4, half-maximal inhibitory concentration: 28100 nM
Compound 4: the middle estimate sits 2.1-fold (0.33 log units) above what was measured; the measured number falls inside the stated range.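

With 2,5-dimethoxyphenyl on the aromatic nitrogen, compound 4 gives the first number rather than a limit in this assay. The comparisons yield an at least 1.7-fold lower number from compound 3 to compound 4 (0.25 log units; that floor lies within the scatter), an at least 1.7-fold lower number from compound 2 to compound 4 (0.25 log units; that floor lies within the scatter) and an at least 1.7-fold lower number from compound 1 to compound 4 (0.25 log units; that floor lies within the scatter), so each shows only a minimum size, and none establishes a real difference. The steps among compound 1, compound 2 and compound 3 remain unreadable because these values share a limit: the limit of > 50000 nM in this assay, at which 3 of the 4 values shown sit.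

Going by these compounds, whether the methoxy groups themselves matter remains open, as does whether a hydroxyl or an amine on the same phenyl ring would give a lower number.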